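The source may report more compounds than this note shows. Statements on the series, on what has been measured and on what is new or still open speak of the compounds shown alone.

Compound 3 `CC(=O)c1ccccc1OC(C)C1=NCCN1` gives 0.6 in an assay on CHO cells with Alpha-2B adrenergic receptor (Homo sapiens) as the target (on this read-out lower numbers stand for smaller maximal responses and higher numbers for larger maximal responses), the highest of the three numbers shown, yet compound 1 `CCOc1ccccc1OC(C)C1=NCCN1` with 0.5 and compound 2 `CC(C)Oc1ccccc1OC(C)C1=NCCN1` with 0.5 both sit within the scatter of it. The two exchanges made at the same aromatic carbon were a number 0.10 higher from compound 1 to compound 3 (within the scatter) and a number 0.10 higher from compound 2 to compound 3 (within the scatter), and the step of no change at the digits printed from compound 1 to compound 2 (within the scatter) elsewhere on the core was likewise flat. Compound 4 `C=COc1ccccc1OC(C)C1=NCCN1` differs from compound 3 by vinyloxy in place of acetyl on an aromatic carbon. Because the step a number 0.10 higher from compound 1 to compound 3 (within the scatter) and the step a number 0.10 higher from compound 2 to compound 3 (within the scatter) at this carbon both stayed within the scatter, no step beyond the scatter is expected in this assay here either; the estimated step is a number 0.050 lower from compound 3 to compound 4 (within the scatter). Compound 4 is therefore estimated at 0.55, with a range from 0.4 to 0.7.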

Compound 4, intrinsic activity: the largest response reached, as a fraction of the reference agonist's: 0.45
Compound 4: the middle estimate sits 0.10 above what was measured; measured number inside the range.
By their numbers in this assay, from the lowest: compounds 4, 1, 2 and 3 (each within the scatter of the next, the first and the last beyond it).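

In this assay, this aromatic carbon now gives its first step beyond the scatter (a number 0.15 lower from compound 3 to compound 4 (beyond the scatter)), even though acetyl and vinyloxy have the same atoms, joined differently. The group on the oxygen still makes little difference: vinyl in place of isopropyl gives (a number 0.050 lower from compound 2 to compound 4 (within the scatter)), and vinyl in place of ethyl gives (a number 0.050 lower from compound 1 to compound 4 (within the scatter)). Nothing available explains the step from acetyl to vinyloxy. On these data alone, whether an amine or a carboxylic acid on this aromatic carbon would shift the maximal response further remains open.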